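The source may report more compounds than this note shows. Statements on the series, on what has been measured and on what is new or still open speak of the compounds shown alone.

Going by the values given here, in an ADME assay on L02 cells (Homo sapiens) for cytotoxicity, read by MTT assay, with a stated time of 48 h (on this read-out lower numbers stand for stronger inhibition and higher numbers for weaker inhibition), two compounds built on one shared core have numbers so far. Compound 1 `CCOC(=O)CN(C)C(=O)c1ccc(C(CC)(CC)c2ccc(OCC(O)C(C)(C)C)c(C)c2)n1CC` gives 10100 nM, and compound 2 `C=CCN(C)C(=O)c1ccc(C(CC)(CC)c2ccc(OCC(O)C(C)(C)C)c(C)c2)n1CC` gives 6300 nM. The two values lie within the scatter of each other, so compound 2 stands level with compound 1. Compound 3 `CCn1c(C(=O)N(CCC#N)CCC#N)ccc1C(CC)(CC)c1ccc(OCC(O)C(C)(C)C)c(C)c1` keeps the shared core and differs from compound 2 in one place: a group of 9 heavy atoms (6 carbon, 3 nitrogen; no ring) in place of a group of 5 heavy atoms (4 carbon, 1 nitrogen; no ring), on a carbonyl carbon. Among the compounds with values here, the only measured step that bears on this is the one reaching compound 2, a 1.6-fold lower number from compound 1 to compound 2 (0.20 log units; within the scatter), which also altered the substituents on the amide-type nitrogen and stayed within the scatter. One small step is thin evidence for a larger group, so the range must stay wide. The expected step, a 1.3-fold higher number from compound 2 to compound 3 (0.10 log units; within the scatter), is none beyond the scatter in this assay. Compound 3 is estimated at 8000 nM, with an expected range of 3000 nM to 20000 nM.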

Compound 3, half-maximal inhibitory concentration: 1700 nM
Estimate against measurement, compound 3: 4.7-fold (0.67 log units) above, outside the stated range (below it).
By their numbers in this assay, from the lowest: compound 3; then compounds 2 and 1 (each within the scatter of the next).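

In this assay, the group on the carbonyl carbon now shifts the number beyond the scatter: the group of 9 heavy atoms, with its 2 triple bonds, gives a 3.7-fold lower number from compound 2 to compound 3 (0.57 log units; beyond the scatter) in place of allyl(methyl)amino and a 5.9-fold lower number from compound 1 to compound 3 (0.77 log units; beyond the scatter) in place of the group that compound 1 carries there. Going by these compounds alone, until now, the two groups compared at this position had stayed within the scatter of each other, so this is the first sign that the assay responds to a change here, and the response is towards stronger inhibition. No measurement available accounts for this shift.

From the compounds shown here alone, whether the step follows the nitrile ends or the chains themselves remains open. A single nitrile-bearing chain, or plain butyl chains on the amide-type nitrogen, would separate the two.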